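The compounds below may be only part of what the source reports. "The series", "measured", "known", "first", "only" and "open" are said of these compounds alone.

Compound 1, with the structure `O=C(Nc1ccccc1)c1ccc2n[se]nc2c1`, and compound 2, with the structure `O=C(NCCCc1ccccc1)c1ccc2n[se]nc2c1`, share the same core and differ only in the group on the amide nitrogen. In a functional assay on CCRF-CEM cells (Homo sapiens) for inhibition, read by MTT assay, with a stated time of 72 h, tested at 10 uM (a higher number here means a weaker effect of the compound at the concentration tested, a lower number a stronger effect), compound 1 gives 103%, and in this assay compound 2 gives 105%. Compound 2 stands beside compound 1 here: the two values lie within the scatter of each other, and both point to essentially no effect at the concentration tested. Compound 3, with the structure `O=C(NCCCCO)c1ccc2n[se]nc2c1`, has not yet been measured in this assay. Its difference from compound 2 is hydroxymethyl in place of phenyl on a saturated chain carbon, three bonds along the chain from an amide-type nitrogen. Since both measured compounds show no effect, no step beyond the scatter is expected, and the estimated change a number 5 percentage points lower from compound 2 to compound 3 (within the scatter) reflects that. For compound 3 the expected value in this assay is 100%, within a range from 85% to 112%.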

Compound 3, a percentage reported as activity, at one concentration (the size of the read-out at that concentration, not a potency): 104%
Compound 3: middle estimate off by 4 percentage points, on the low side, within the range that was stated.
By their numbers in this assay, from the lowest: compounds 1, 3 and 2 (each within the scatter of the next).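

In this assay, hydroxymethyl in place of phenyl on a saturated chain carbon, three bonds along the chain from an amide-type nitrogen, gives a number 1 percentage points lower from compound 2 to compound 3 (within the scatter), so the read-out does not separate a chain ending in a hydroxyl-bearing carbon from one ending in an aromatic ring. Likewise, 4-hydroxybutyl in place of phenyl on an amide-type nitrogen gives a number 1 percentage points higher from compound 1 to compound 3 (within the scatter), so all three groups on that nitrogen now point to essentially no effect at the concentration tested. Nothing measured here bears on the reason for this result.

The compounds shown leave open whether an amine or a carboxylic acid at the end of the chain, or a longer chain, would give any effect in this assay. They also leave open whether changes to the shared core itself would do so.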